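From benzoyl to methoxymethyl on the shared core

This account rests on a few compounds, and the source may have more. Where it says the series, first, only, none or still open, it means among the compounds named here.

- compound 1 `CC(C)=CCC[C@]1(C)/C=C/[C@@H](OC(=O)C(C)C)[C@](C)(O)/C=C/C(=O)/C(CO)=C\C1`: 8510 nM
- compound 2 `CCCC(=O)O[C@@H]1/C=C/[C@@](C)(CCC=C(C)C)C/C=C(/CO)C(=O)/C=C/[C@@]1(C)O`: 2510 nM
- compound 3 `CC(C)=CCC[C@]1(C)/C=C/[C@@H](OC(=O)c2ccccc2)[C@](C)(O)/C=C/C(=O)/C(CO)=C\C1`: 10300 nM

In a functional assay on SW480 cells (Homo sapiens) for antiproliferative activity, read by MTT assay, with a stated time of 48 h (a higher number here means a weaker inhibitor, a lower number a stronger inhibitor), compound 3 stands at the high-number end of the set, a place it shares: a 1.2-fold higher number from compound 1 to compound 3 (0.08 log units; within the scatter) stays inside the scatter, whereas a 4.1-fold higher number from compound 2 to compound 3 (0.61 log units; beyond the scatter) does not. Compound 4 `COCO[C@@H]1/C=C/[C@@](C)(CCC=C(C)C)C/C=C(/CO)C(=O)/C=C/[C@@]1(C)O` is unmeasured and carries methoxymethyl in place of benzoyl on an oxygen on a saturated carbon, that is, methoxymethyl in place of benzoyl on an oxygen on a saturated carbon. Among the measured compounds shown here, the nearest evidence is the swaps on the carbonyl carbon, such as a 3.4-fold lower number from compound 1 to compound 2 (0.53 log units; beyond the scatter), and no measured compound lacks that carbonyl. A step beyond the modest size of these swaps is therefore not expected, and most likely none beyond the scatter, with a lean towards a lower number. The expected shift is a 1.7-fold lower number from compound 3 to compound 4 (0.23 log units; within the scatter) as an estimate. For compound 4 the estimated value is 6000 nM, with an expected range of 2000 nM to 18000 nM.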

Compound 4, half-maximal inhibitory concentration: > 40000 nM
Compound 4: a limit, no number; the forecaster's own chance of this, stated with the estimate: 8%; at least 6.6-fold (0.82 log units) between middle value and limit.
By their numbers in this assay, from the lowest: compound 2; then compounds 1 and 3 (each within the scatter of the next). At a limit, above all of these: compound 4.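

In this assay, compound 4 gives a limit and no number: the limit of > 40000 nM in this assay, at which 1 of the 4 values shown sits. Methoxymethyl on this oxygen on a saturated carbon gives a step beyond the scatter against each ester: an at least 3.8-fold higher number from compound 3 to compound 4 (0.58 log units; beyond the scatter), an at least 4.7-fold higher number from compound 1 to compound 4 (0.67 log units; beyond the scatter) and an at least 15-fold higher number from compound 2 to compound 4 (1.20 log units; beyond the scatter). The swaps on the carbonyl carbon all left a readable number, so this position tolerates changes to the group on the carbonyl less well than it tolerates no carbonyl at all, at least for methoxymethyl.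

The compounds shown leave open whether the loss follows from removing the carbonyl or from methoxymethyl itself. A free hydroxyl or a methyl ether at this oxygen would separate the two.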